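A few compounds are considered here, and "the series" means these few. Any claim that something is new, unique, unknown or untested is made for them only; others in the source may bear on it.

Compounds measured so far in a functional assay on NCI-H1975 cells (Homo sapiens) for antiproliferative activity, read by MTT assay, with a stated time of 72 h; on this read-out lower numbers stand for stronger inhibition and higher numbers for weaker inhibition:
- compound 1 `COc1cc(N(C)CCN(C)C)c(NC(=O)c2ccnc(O)c2)cc1Nc1nccc(-c2cn(C)c3ccccc23)n1`: 12000 nM
- compound 2 `COc1cc(N(C)CCN(C)C)c(NC(=O)c2cccnc2)cc1Nc1nccc(-c2cn(C)c3ccccc23)n1`: 1750 nM
- compound 3 `COc1cc(N(C)CCN(C)C)c(NC(=O)c2ccncn2)cc1Nc1nccc(-c2cn(C)c3ccccc23)n1`: 1560 nM

Compound 3 gives the lowest number of the three in this assay, but its separation from compound 2 is within the scatter (a 1.1-fold lower number from compound 2 to compound 3 (0.05 log units; within the scatter)), so the two cannot be ordered; only compound 1 stands apart, the step of a 7.7-fold lower number from compound 1 to compound 3 (0.89 log units; beyond the scatter) being beyond the scatter.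

Compound 4 `COc1cc(N(C)CCN(C)C)c(NC(=O)c2ncccn2)cc1Nc1nccc(-c2cn(C)c3ccccc23)n1` differs from compound 3 by pyrimidin-2-yl in place of pyrimidin-4-yl on a carbonyl carbon. For the measured compounds named here, the one measured step of comparable kind, a change of the heteroaryl ring on the same carbonyl carbon between compound 2 and compound 3, was within the scatter. A step beyond the scatter in this assay is therefore not expected here; the estimated change is a 1.2-fold higher number from compound 3 to compound 4 (0.06 log units; within the scatter). Compound 4 is expected to give about 1800 nM, in the range 700 nM to 4500 nM.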

Compound 4, half-maximal inhibitory concentration: 650 nM
For compound 4 the middle estimate is 2.8-fold (0.44 log units) above the measured one, outside the stated range (below it).
By their numbers in this assay, from the lowest: compound 4; then compounds 3 and 2 (each within the scatter of the next); then compound 1.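

In this assay, pyrimidin-2-yl in place of pyrimidin-4-yl on a carbonyl carbon gives a 2.4-fold lower number from compound 3 to compound 4 (0.38 log units; beyond the scatter) and so separates two rings with the same atom counts, which the earlier heteroaryl swap between pyridin-3-yl and pyrimidin-4-yl did not do. The same ring in place of pyridin-3-yl gives a 2.7-fold lower number from compound 2 to compound 4 (0.43 log units; beyond the scatter) and in place of 2-hydroxypyridin-4-yl gives an 18-fold lower number from compound 1 to compound 4 (1.27 log units; beyond the scatter) as the largest step shown. Nothing available explains why the two pyrimidinyl attachments differ.

Open, as far as these compounds go, is how a pyrazinyl ring on the same carbonyl carbon would compare with pyrimidin-2-yl. Also open, from the compounds shown here alone, is whether an amino or methyl group on the pyrimidin-2-yl ring would keep the lower number.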